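This account rests on a few compounds, and the source may have more. Where it says the series, first, only, none or still open, it means among the compounds named here.

Going by the values given here, the compounds measured so far in an ADME assay on Vero cells (Chlorocebus sabaeus) for cytotoxicity, read by MTT assay, with a stated time of 72 h (a lower number here means that less compound is tolerated, a higher number that more compound is tolerated), are these.

Compound 1 `CCO/N=C1\C(=O)N(CCCCCOc2ccc3oc(-c4ccc(OC)cc4)c(C(=O)OCC)c3c2)c2ccc(OC)cc21` gives 16 ug/mL
Compound 2 `CCOC(=O)c1c(-c2ccccc2)oc2ccc(OCCCN3C(=O)/C(=N\OC)c4ccccc43)cc12` gives 64 ug/mL
Compound 3 `CCOC(=O)c1c(-c2ccc(OC)cc2)oc2ccc(OCCCN3C(=O)/C(=N\OC)c4ccccc43)cc12` gives 128 ug/mL

Compound 3 has the highest of the three numbers, although compound 2 lies within the scatter of it. Compound 1 lies lower, beyond the scatter.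

The next compound, compound 4 `CCO/N=C1\C(=O)N(CCCOc2ccc3oc(-c4ccc(OC)cc4)c(C(=O)OCC)c3c2)c2ccccc21`, differs from compound 3 by methyl in place of hydrogen on a saturated chain carbon bound to an oxygen on an unsaturated carbon. This is methyl in place of hydrogen on a saturated chain carbon bound to an oxygen on an unsaturated carbon, which reads as methoxy to ethoxy.

Among the compounds with values here, no measured step makes this change. The only one, a 2.0-fold higher number from compound 2 to compound 3 (0.30 log units; within the scatter), is a different change in a different place and bears on it only loosely. Compound 1 also carries ethoxy, but it differs from compound 4 in other places too, so compound 1 with 16 ug/mL does not isolate this change. No shift beyond the scatter is therefore expected in this assay, and no direction can be argued. The estimated change is a 1.4-fold lower number from compound 3 to compound 4 (0.15 log units; within the scatter). For compound 4 the expected value is 90 ug/mL, with an estimated range of 32 ug/mL to 256 ug/mL.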

Compound 4, half-maximal cytotoxic concentration: 16 ug/mL
The estimate for compound 4 lay 5.6-fold (0.75 log units) above the measured number; measured number below the stated range.
By their numbers in this assay, from the lowest: compounds 1 and 4 (each within the scatter of the next); then compounds 2 and 3 (each within the scatter of the next).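

In this assay, going by these compounds alone, methoxy to ethoxy gives the first measured step at this position (an 8.0-fold lower number from compound 3 to compound 4 (0.90 log units; beyond the scatter)), and it lies beyond the scatter. Within the data shown here, a single methyl in place of hydrogen, on a saturated chain carbon bound to an oxygen on an unsaturated carbon, is therefore enough to move the number by more than repeated measurements would, whereas the only earlier step (a 2.0-fold higher number from compound 2 to compound 3 (0.30 log units; within the scatter)) lay within the scatter and was a different change in a different place. Nothing measured here accounts for this shift.

On these data alone, it remains open whether a longer chain at this position, such as propoxy or butoxy, would lower the number further or leave it where ethoxy puts it. It is also open whether a hydroxyl or an amine at the end of that chain would reverse the step, and whether the step would recur on the other compounds shown.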